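A second 4-methoxybenzyl group on a series at its limit

The source may report more compounds than this note shows. Statements on the series, on what has been measured and on what is new or still open speak of the compounds shown alone.

Compound 1 (`COc1ccc2c(c1)cc(-c1cc(OC)c(OC)c(OC)c1)n2Cc1ccccc1`) gives > 30000 nM in a functional assay on MCF7 cells (Homo sapiens) for cytotoxicity, read by MTT assay, with a stated time of 24 h (a higher number here means a weaker inhibitor, a lower number a stronger inhibitor), and that is a limit, not a number. Compound 2 (`COc1ccc(Cn2c(-c3cc(OC)c(OC)c(OC)c3)cc3cc(OC)ccc32)cc1`) gives > 30000 nM in this assay and that is also a limit. Compound 2 therefore stands at the limit of > 30000 nM in this assay, at which 2 of the 2 values shown sit, and has no numerical position in the series. Going by the values given here, the only measured step is a step that the two limits leave unreadable from compound 1 to compound 2 and it offers no size to carry forward.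

Compound 3 (`COc1ccc(Cc2c(-c3cc(OC)c(OC)c(OC)c3)n(Cc3ccc(OC)cc3)c3ccc(OC)cc23)cc1`) differs from compound 2 by one change: 4-methoxybenzyl in place of hydrogen on an aromatic carbon. In words, 4-methoxybenzyl stands in place of hydrogen on an aromatic carbon, next to the ring atom that bears a 3,4,5-trimethoxyphenyl group. Among the compounds with values here, no measured step covers this kind of change, so the expectation rests only on the series sitting at its limit so far. No step beyond the scatter is expected, in either direction, and another limit is the likeliest report. The estimate in this assay is a number no higher from compound 2 to compound 3 (the limit leaves the size open) in size and has no clear direction. For compound 3 the estimated value is 30000 nM with an expected range of 8000 nM to 60000 nM in this reading.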

Compound 3, half-maximal inhibitory concentration: > 30000 nM
Compound 3 was reported as a limit (the forecaster's own chance of this, stated with the estimate: 70%); the middle value lies on the limit itself.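

In this assay compound 3 gives > 30000 nM, and that is a limit. No step can be read from compound 2 to compound 3, nor from compound 1 to compound 2. The compounds shown leave open whether either change has any effect of measurable size, with the whole series standing at one point: the limit of > 30000 nM in this assay, at which 3 of the 3 values shown sit.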